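Working notes: changing the aryl group on the shared core

A few compounds are considered here, and "the series" means these few. Any claim that something is new, unique, unknown or untested is made for them only; others in the source may bear on it.

Compound 1 `Cc1cc(Nc2cc(N3CCN(C)CC3)nc(Nc3ccc([N+](=O)[O-])cc3)n2)n[nH]1`: 1630 nM
Compound 2 `Cc1cc(Nc2cc(N3CCN(C)CC3)nc(Nc3cccc(Cl)c3)n2)n[nH]1`: 736 nM

Compound 2 has the lower of the two numbers in a functional assay on HCT-116 cells (Homo sapiens) for antiproliferative activity, read by CCK-8 assay, with a stated time of 72 h; on this read-out lower numbers stand for stronger inhibition and higher numbers for weaker inhibition. Compound 3 `COc1ccc(Nc2nc(Nc3cc(C)[nH]n3)cc(N3CCN(C)CC3)n2)cc1` differs from it as follows: 4-methoxyphenyl in place of 3-chlorophenyl on a nitrogen on an aromatic ring. That is, 4-methoxyphenyl in place of 3-chlorophenyl on a nitrogen on an aromatic ring. Among the measured compounds shown here, one measured step bears on this position: a 2.2-fold lower number from compound 1 to compound 2 (0.35 log units; beyond the scatter), which is modest and beyond the scatter. For the measured compounds named here, no measured compound carries 4-methoxyphenyl, so direction is uncertain. A modest rise is expected, and the estimated step is a 1.4-fold higher number from compound 2 to compound 3 (0.13 log units; within the scatter). For compound 3 the estimated value is 1000 nM, with an expected range of 400 nM to 2500 nM.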

Compound 3, half-maximal inhibitory concentration: 2240 nM
Estimate against measurement, compound 3: 2.2-fold (0.35 log units) below, within the range that was stated.
By their numbers in this assay, from the lowest: compound 2; then compounds 1 and 3 (each within the scatter of the next).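

In this assay, the aryl group on this nitrogen now shows a change in both directions: 4-methoxyphenyl in place of 3-chlorophenyl gives the larger step (a 3.0-fold higher number from compound 2 to compound 3 (0.48 log units; beyond the scatter)), beyond the scatter. Methoxy in place of nitro gives a step within the scatter (a 1.4-fold higher number from compound 1 to compound 3 (0.14 log units; within the scatter)), so these two groups are not separated here, and 3-chlorophenyl alone stands apart from both. No evidence is available to explain these differences.

Open, on these data alone, is whether the chlorine itself or its ring position matters, as the groups compared differ in both. A 4-chlorophenyl or 3-methoxyphenyl group would separate these two factors.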